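Swapping the Benzyl Substituent: Compound 2 to Compound 3

The source may report more compounds than this note shows. Statements on the series, on what has been measured and on what is new or still open speak of the compounds shown alone.

Compound 1 `COc1ccc([C@@H]2CC(=O)c3c(O)cc(OCc4cn(C)nn4)cc3O2)cc1O`: 15200 nM
Compound 2 `COc1ccc([C@@H]2CC(=O)c3c(O)cc(OCc4cn(Cc5cccc(C)c5)nn4)cc3O2)cc1O`: 17400 nM

In a functional assay on RAW264.7 cells (Mus musculus) for inhibition, read by Griess assay, with stated times of 2 h and 24 h (on this read-out higher numbers stand for weaker inhibition and lower numbers for stronger inhibition), compound 2 holds the upper of the two numbers, yet its gap to compound 1 lies within the scatter, as the step of a 1.1-fold higher number from compound 1 to compound 2 (0.06 log units; within the scatter) shows. Compound 3 `COc1ccc([C@@H]2CC(=O)c3c(O)cc(OCc4cn(Cc5ccc(F)cc5)nn4)cc3O2)cc1O` differs from compound 2 by 4-fluorophenyl in place of 3-methylphenyl on a saturated chain carbon bound to an aromatic nitrogen. Going by the values given here, the only step at this position, a 1.1-fold higher number from compound 1 to compound 2 (0.06 log units; within the scatter), was within the scatter, so no movement beyond the scatter is expected in this assay for compound 3. The estimate for compound 3 is therefore 16000 nM, ranging from 7500 nM to 34000 nM. The expected step of a 1.1-fold lower number from compound 2 to compound 3 (0.04 log units; within the scatter) is essentially flat.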

Compound 3, half-maximal inhibitory concentration: 15100 nM
Beside the measured number, compound 3's estimate is 1.1-fold (0.03 log units) above it, within the range that was stated.
By their numbers in this assay, from the lowest: compounds 3, 1 and 2 (each within the scatter of the next).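

In this assay a second aryl group at this position again leaves the reading flat: a 1.2-fold lower number from compound 2 to compound 3 (0.06 log units; within the scatter), and a 1.0-fold lower number from compound 1 to compound 3 (0.00 log units; within the scatter). Thus 4-fluorophenyl and 3-methylphenyl, on a saturated chain carbon bound to an aromatic nitrogen, both read alike with the hydrogen of compound 1, and the two aryl groups cannot be told apart here. Nothing at hand accounts for this flat result. As far as these compounds go, whether an amine, a carboxylic acid or a longer chain in this place would move the number beyond the scatter stays open.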